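This account rests on a few compounds, and the source may have more. Where it says the series, first, only, none or still open, it means among the compounds named here.

Among the measured compounds shown here, in a functional assay on MC-38 cells (Mus musculus) for antiproliferative activity (on this read-out higher numbers stand for weaker inhibition and lower numbers for stronger inhibition), two compounds with a shared core have numbers so far. Compound 1 `COc1ccc(S(=O)(=O)Nc2cccc3c(Cl)c[nH]c23)cc1` gives 0.2 ug/mL, and compound 2 `CS(=O)(=O)Nc1ccc(S(=O)(=O)Nc2cccc3c(Cl)c[nH]c23)cc1` gives 0.26 ug/mL. These values lie within the usual scatter of each other, so the two compounds cannot be told apart on this read-out.

The next molecule, compound 3 `CNS(=O)(=O)c1ccc(S(=O)(=O)Nc2cccc3c(Cl)c[nH]c23)cc1`, keeps the core of compound 2 and differs in one group: methylsulfamoyl in place of methanesulfonamido on an aromatic carbon. Methylsulfamoyl takes the place of methanesulfonamido on an aromatic carbon, with the same atoms joined differently.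

For the measured compounds named here, only one measured step bears on this change, a 1.3-fold higher number from compound 1 to compound 2 (0.11 log units; within the scatter), in which methanesulfonamido replaced methoxy on an aromatic carbon. That step stayed within the scatter. Going by the values given here, it is a single step, however, and no measured compound carries methylsulfamoyl, so the evidence is thin and the range must stay wide. No shift beyond the scatter is expected in this assay, and the expected step is a 1.0-fold lower number from compound 2 to compound 3 (0.02 log units; within the scatter). Compound 3 is estimated at 0.25 ug/mL, with an expected range from 0.1 ug/mL to 0.6 ug/mL.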

Compound 3, half-maximal inhibitory concentration: 0.24 ug/mL
Beside the measured number, compound 3's estimate is 1.0-fold (0.02 log units) above it; low and high end bracket the measured number.
By their numbers in this assay, from the lowest: compounds 1, 3 and 2 (each within the scatter of the next).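

Rejoining the same atoms, so that methylsulfamoyl stands in place of methanesulfonamido on the aromatic carbon, gives a 1.1-fold lower number from compound 2 to compound 3 (0.03 log units; within the scatter) in this assay, so the two ways of joining these atoms cannot be told apart on this read-out. Methylsulfamoyl in place of methoxy gives a 1.2-fold higher number from compound 1 to compound 3 (0.08 log units; within the scatter), which is also within the scatter, so three different groups have now been compared at this place, para to a large group, without any measurable separation among compounds 1, 2 and 3. Nothing measured here accounts for why these changes leave the number so little moved.

The compounds shown leave open whether this even picture would hold for a quite different group at the same place, such as a carboxylic acid, an amine or a longer alkyl chain. They also leave open whether a change elsewhere in the shared core, for example replacing the chlorine with a hydrogen or a methyl group, would move the number any further than these three groups do.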